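Removing the ethoxy group from compound 1

The source may hold more compounds than are shown below. What is called first, only, known or untested is meant among the compounds shown, and "the series" means these compounds.

compound 1 `CCOc1ccc(/C=N/NC(=O)COc2cccc3ccccc23)cc1O`: 6.23 ug/mL
compound 2 `O=C(COc1cccc2ccccc12)N/N=C/c1ccc(O)cc1`: 26.5 ug/mL

Both compounds were tested in an ADME assay on MT4 cells (Homo sapiens) for cytotoxicity, read by MTT assay, with a stated time of 4 days (a lower number here means that less compound is tolerated, a higher number that more compound is tolerated), and compound 1 stands lowest of the two, at 6.23 ug/mL against the number of compound 2 at 26.5 ug/mL. That gap lies beyond the usual scatter, so compound 1 is the less tolerated of this small pair.

The next compound to be measured is compound 3 `O=C(COc1cccc2ccccc12)N/N=C/c1cccc(O)c1`. Its structure differs from that of compound 1 in one place: hydrogen in place of ethoxy on an aromatic carbon. Hydrogen takes the place of ethoxy on an aromatic carbon, ortho to a hydroxy group and para to a large group.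

Within the data shown here, no measured pair shows this change on its own, so the size of the step is uncertain. Among the measured compounds shown here, the only guide is that compound 2 at 26.5 ug/mL sits on the higher side of compound 1 in this assay. A rise beyond the scatter is therefore expected, and the estimated move is a 3.2-fold higher number from compound 1 to compound 3 (0.51 log units; beyond the scatter) in that direction. The estimated value for compound 3 is 20 ug/mL, with an expected range from 8 ug/mL to 50 ug/mL.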

Compound 3, half-maximal cytotoxic concentration: 32.6 ug/mL
Beside the measured number, compound 3's estimate is 1.6-fold (0.21 log units) below it, and the stated range covers the measured number.
By their numbers in this assay, from the lowest: compound 1; then compounds 2 and 3 (each within the scatter of the next).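

In this assay, the exchange of ethoxy for hydrogen on the aromatic carbon, ortho to a hydroxy group and para to a large group, now has a measured size of its own (a 5.2-fold higher number from compound 1 to compound 3 (0.72 log units; beyond the scatter)), and this single change lies beyond the scatter. The second step concerns the hydroxy group rather than the ethoxy group: with no ethoxy present, 3-hydroxyphenyl in place of 4-hydroxyphenyl on the carbon with a double bond to nitrogen gives a difference within the scatter (a 1.2-fold higher number from compound 2 to compound 3 (0.09 log units; within the scatter)), so this exchange does not separate compound 2 from compound 3 in this assay. Nothing available here explains why the exchange of ethoxy for hydrogen is followed by this step.

The compounds shown rest on ethoxy and hydrogen alone at this carbon, so it remains open where a methoxy group, a longer alkoxy chain, a fluorine or an amine there would fall relative to compound 1 and compound 3. Going by these compounds, it is also open whether the step seen here would recur on a core other than that of compound 1.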